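Swapping Fluoro for Chloro: Little Change Expected in Binding

A few compounds are considered here, and "the series" means these few. Any claim that something is new, unique, unknown or untested is made for them only; others in the source may bear on it.

Two compounds have so far been measured in an assay on CHO cells for displacement of a labelled ligand from adenosine receptor A1 (Homo sapiens); a lower number here means tighter binding, a higher number weaker binding:
Compound 1 `Nc1scc(CN2CCN(C3CCCCC3)CC2)c1C(=O)c1ccc(Cl)cc1`: 1.1 nM
Compound 2 `Nc1scc(CN2CCN(c3ccc(F)cc3)CC2)c1C(=O)c1ccc(Cl)cc1`: 1 nM

Among the compounds with values here, compound 2 carries the lowest of these two numbers, but its only neighbour sits very close: the step of a 1.1-fold lower number from compound 1 to compound 2 (0.04 log units; within the scatter) lies within the scatter, so the two compounds cannot be ranked against each other.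

Compound 3 `Nc1scc(CN2CCN(c3ccc(Cl)cc3)CC2)c1C(=O)c1ccc(Cl)cc1` differs from compound 2 in one place: chloro in place of fluoro on an aromatic carbon. Within the data shown here, the one measured step, from cyclohexyl to 4-fluorophenyl, concerns a different position and was itself within the scatter, so no measured step bears directly on this change. With nothing in the shown data pointing either way, the step is expected to be a 1.1-fold higher number from compound 2 to compound 3 (0.04 log units; within the scatter), that is, none beyond the scatter. Compound 3 is therefore estimated at 1.1 nM, with a range from 0.4 nM to 3 nM.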

Compound 3, dissociation constant: 1.1 nM
The estimate for compound 3 equals the measured number at the digits printed, within the range that was stated.
By their numbers in this assay, from the lowest: compounds 2, 1 and 3 (each within the scatter of the next).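

In this assay, within the data shown here, the first measured change on this aromatic carbon gives a 1.1-fold higher number from compound 2 to compound 3 (0.04 log units; within the scatter), so fluoro and chloro cannot be told apart at this position. Putting 4-chlorophenyl in place of cyclohexyl on the amine nitrogen in the ring gives no change at the digits printed from compound 1 to compound 3 (within the scatter), which means that a second substituted phenyl group also shows no step beyond the scatter from cyclohexyl. No outside measurement is available to help interpret these results.

Only fluoro and chloro are shown on this aromatic carbon, so the effect of an amine or a carboxylic acid there remains open. It is also unknown whether any group on the amine nitrogen can move the number beyond the scatter, as cyclohexyl, 4-fluorophenyl and 4-chlorophenyl all lie within it.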